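The compounds below may be only part of what the source reports. "The series", "measured", "known", "first", "only" and "open" are said of these compounds alone.

Among the compounds with values here, compound 3 `COC(=O)CC(=O)NC1=CS(=O)(=O)O[C@@]12[C@@H](CO[Si](C)(C)C(C)(C)C)O[C@@H](n1cc(C)c(=O)n(C)c1=O)[C@@H]2O[Si](C)(C)C(C)(C)C` gives 11900 nM in a functional assay on MT4 cells (Homo sapiens) (a higher number here means that more compound is tolerated, a lower number that less compound is tolerated), the second highest of the three numbers measured so far. Its nearest neighbour is compound 2 `Cc1cn([C@@H]2O[C@H](CO[Si](C)(C)C(C)(C)C)[C@@]3(OS(=O)(=O)C=C3NCCC(N)=O)[C@H]2O[Si](C)(C)C(C)(C)C)c(=O)n(C)c1=O`, which gives 20000 nM in this assay, a gap within the scatter. The furthest is compound 1 `Cc1cn([C@@H]2O[C@H](CO[Si](C)(C)C(C)(C)C)[C@@]3(OS(=O)(=O)C=C3NC(=O)c3ccccc3)[C@H]2O[Si](C)(C)C(C)(C)C)c(=O)n(C)c1=O`, which gives 4900 nM in this assay, and the step of a 2.4-fold higher number from compound 1 to compound 3 (0.39 log units; beyond the scatter) lies beyond the scatter.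

Compound 4 `COC(=O)CCNC1=CS(=O)(=O)O[C@@]12[C@@H](CO[Si](C)(C)C(C)(C)C)O[C@@H](n1cc(C)c(=O)n(C)c1=O)[C@@H]2O[Si](C)(C)C(C)(C)C` differs from compound 3 in one place: 2-(methoxycarbonyl)ethyl in place of ((methoxycarbonyl)methyl)carbonyl on an amine nitrogen.

Within the data shown here, two measured steps bear on this. The step of a 4.1-fold higher number from compound 1 to compound 2 (0.61 log units; beyond the scatter) put a chain without a carbonyl on the amine nitrogen in place of a group bearing one and moved the number up. The step of a 1.7-fold lower number from compound 2 to compound 3 (0.23 log units; within the scatter) went the other way, putting a carbonyl-bearing group back on that nitrogen, and stayed within the scatter. The change to compound 4 again removes the carbonyl from the amine nitrogen, so a modest rise or no step beyond the scatter is expected in this assay, that is a 1.4-fold higher number from compound 3 to compound 4 (0.15 log units; within the scatter).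

Compound 4 is therefore estimated at 17000 nM in this assay, with a range from 7500 nM to 38000 nM.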

Compound 4, half-maximal cytotoxic concentration: > 250000 nM
Compound 4 gave a limit, no number; the forecaster's own chance of this, stated with the estimate: 10%; at least 14-fold (1.16 log units) between middle value and limit.
By their numbers in this assay, from the lowest: compound 1; then compounds 3 and 2 (each within the scatter of the next). At a limit, above all of these: compound 4.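

In this assay compound 4 gives a limit and not a number: the limit of > 250000 nM in this assay, at which 1 of the 4 values shown sits. Within the data shown here, the amine nitrogen proves far more sensitive to its substituent than the earlier compounds showed, with an at least 21-fold higher number from compound 3 to compound 4 (1.32 log units; beyond the scatter) and an at least 51-fold higher number from compound 1 to compound 4 (1.70 log units; beyond the scatter). Loss of the carbonyl on that nitrogen is not enough on its own, and compound 2 goes against that reading: it also carries a chain without that carbonyl and stays within the scatter of compound 3, while methoxy in place of amino on a carbonyl carbon gives an at least 12-fold higher number from compound 2 to compound 4 (1.09 log units; beyond the scatter).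

Going by these compounds, the steps to compound 4 fix only a minimum, so their full size stays open. Also open, on these data alone, is whether a carboxylic acid in place of the methyl ester, or a longer chain on the amine nitrogen, would behave like 2-(methoxycarbonyl)ethyl.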